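Opening the Cyclohexyl Ether of Compound 1 to an Alcohol

The source may report more compounds than this note shows. Statements on the series, on what has been measured and on what is new or still open speak of the compounds shown alone.

The shared core carries an aminocyclohexyl group, and the two measured compounds differ only there. Compound 1 `CO[C@H]1CC[C@H](Nc2cc(NCc3cnccc3C(F)(F)F)ncc2C#N)CC1` gives 1100 nM in an assay on isolated protein for inhibition of protein kinase C theta type (Homo sapiens), read by TR-FRET, with a stated time of 2 h (a lower number here means a stronger inhibitor, a higher number a weaker inhibitor), the highest of the two numbers; compound 2 `CN(C)C(=O)[C@H]1CC[C@@H](Nc2cc(NCc3cnccc3C(F)(F)F)ncc2C#N)CC1` gives 38 nM in this assay, a gap well beyond the scatter. Compound 3 `CC1(C)C[C@@H](Nc2cc(NCc3cnccc3C(F)(F)F)ncc2C#N)CC[C@H]1O` changes compound 1 by 4-hydroxy-3,3-dimethylcyclohexyl in place of 4-methoxycyclohexyl on a nitrogen on an aromatic ring. Going by the values given here, no measured pair shows this change, so the expected step is a modest gain, with the number for compound 3 expected to move a 2.8-fold lower number from compound 1 to compound 3 (0.44 log units; beyond the scatter). Compound 3 is estimated at 400 nM, within 100 nM to 1500 nM.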

Compound 3, half-maximal inhibitory concentration: 120 nM
For compound 3 the middle estimate is 3.3-fold (0.52 log units) above the measured one, within the range that was stated.
By their numbers in this assay, from the lowest: compound 2; then compound 3; then compound 1.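

In this assay, replacing 4-methoxycyclohexyl with 4-hydroxy-3,3-dimethylcyclohexyl on the nitrogen gives a 9.2-fold lower number from compound 1 to compound 3 (0.96 log units; beyond the scatter), so a group with no carbonyl can also give a lower number than compound 1 at this position. Even so, compound 3 at 120 nM stays above compound 2 at 38 nM on the printed values. The change replaces the methyl ether with a hydroxyl and adds two methyl groups at once, and the compounds shown do not separate these two parts. From the compounds shown here alone, whether plain 4-hydroxycyclohexyl or 4-aminocyclohexyl would give a similar number remains open. No evidence available here bears on this result.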